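The compounds below may be only part of what the source reports. "The series", "measured", "known", "first", "only" and "open" are said of these compounds alone.

Compound 2 `COc1ccc(Nc2nccc(-c3cn(C)c4ccccc34)n2)c(OC)c1` and compound 1 `COc1ccc(Nc2nccc(-c3cn(C4CCCC4)c4ccccc34)n2)c(OC)c1` share one core and differ only in the group on the aromatic nitrogen. In an assay for inhibition of MAP kinase-interacting serine/threonine-protein kinase 2 (Homo sapiens), read by TR-FRET (on this read-out higher numbers stand for weaker inhibition and lower numbers for stronger inhibition), compound 2 gives 610 nM, and compound 1 gives 390 nM; the two lie within the scatter of each other, with a 1.6-fold higher number from compound 1 to compound 2 (0.19 log units; within the scatter). Compound 3 `COc1ccc(Nc2nccc(-c3cn(C(C)C)c4ccccc34)n2)c(OC)c1` carries isopropyl in place of methyl on an aromatic nitrogen. Among the measured compounds shown here, the only step that bears on this change is a 1.6-fold higher number from compound 1 to compound 2 (0.19 log units; within the scatter), itself within the scatter, so no step beyond the scatter is expected for compound 3, giving a 1.2-fold lower number from compound 2 to compound 3 (0.09 log units; within the scatter). Compound 3 is therefore estimated at 500 nM, within 250 nM to 1000 nM.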

Compound 3, inhibition constant: 220 nM
Beside the measured number, compound 3's estimate is 2.3-fold (0.36 log units) above it; measured number outside the range, below it.
By their numbers in this assay, from the lowest: compounds 3, 1 and 2 (each within the scatter of the next, the first and the last beyond it).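

On the aromatic nitrogen, this assay now shows a step beyond the scatter: a 2.8-fold lower number from compound 2 to compound 3 (0.44 log units; beyond the scatter) is modest, but the earlier change from cyclopentyl to methyl stayed within it. The step of a 1.8-fold lower number from compound 1 to compound 3 (0.25 log units; within the scatter) also lies within the scatter, so isopropyl and cyclopentyl are not separated here. Nothing available accounts for the step from methyl to isopropyl. Open, on these data alone, is how ethyl, a longer chain or an amine on this nitrogen would read. As far as these compounds go, whether the isopropyl step holds on other cores also remains open.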